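The source may hold more compounds than are shown below. What is called first, only, known or untested is meant among the compounds shown, and "the series" means these compounds.

Working notes on the series. In an assay on CHO cells for displacement of a labelled ligand from adenosine receptor A1 (Homo sapiens) (a higher number here means a weaker inhibitor, a lower number a stronger inhibitor), compound 2 `CCCCc1cn(-c2nc(NC)c3ncn([C@@H]4O[C@H](C(=O)NCC)[C@@H](O)[C@H]4O)c3n2)nn1` gives 750 nM, the second highest of the three numbers measured, with compound 3 `CCCCc1cn(-c2nc(NC)c3ncn([C@@H]4O[C@H](CO)[C@@H](O)[C@H]4O)c3n2)nn1` at 848 nM and compound 1 `CCNC(=O)[C@H]1O[C@@H](n2cnc3c(NC)nc(-n4cc(Cc5ccccc5)nn4)nc32)[C@H](O)[C@@H]1O` at 510 nM, both within the scatter of it. The two measured steps, a 1.5-fold higher number from compound 1 to compound 2 (0.17 log units; within the scatter) and a 1.1-fold higher number from compound 2 to compound 3 (0.05 log units; within the scatter), both stay within the scatter. Compound 4 `CCNC(=O)[C@H]1O[C@@H](n2cnc3c(NC)nc(-n4cc(CC5CCCC5)nn4)nc32)[C@H](O)[C@@H]1O` is not yet measured; it differs from compound 2 by cyclopentyl in place of propyl on a saturated chain carbon bound to an aromatic carbon. The step that bears on this change is a 1.5-fold higher number from compound 1 to compound 2 (0.17 log units; within the scatter), a swap at the same saturated chain carbon, and it remained within the scatter. No step beyond the scatter is therefore expected in this assay for compound 4. Compound 4 is expected near 600 nM, with a range of 250 nM to 1500 nM, which corresponds to an expected step of a 1.3-fold lower number from compound 2 to compound 4 (0.10 log units; within the scatter).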

Compound 4, inhibition constant: 1250 nM
Beside the measured number, compound 4's estimate is 2.1-fold (0.32 log units) below it; the range from low to high includes it.
By their numbers in this assay, from the lowest: compounds 1, 2, 3 and 4 (each within the scatter of the next, the first and the last beyond it).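

In this assay, cyclopentyl in place of propyl on a saturated chain carbon bound to an aromatic carbon gives a 1.7-fold higher number from compound 2 to compound 4 (0.22 log units; within the scatter) and so stays within the scatter. Cyclopentyl in place of phenyl at the same carbon gives a 2.5-fold higher number from compound 1 to compound 4 (0.39 log units; beyond the scatter) and is the first step in the series beyond the scatter, though modest. Nothing available accounts for this difference. Still open, from the compounds shown here alone, is whether an amine or a carboxylic acid on this chain carbon would move the number further.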